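The source may report more compounds than this note shows. Statements on the series, on what has been measured and on what is new or still open speak of the compounds shown alone.

The three compounds with a measured value are these:

compound 1 `CC#C[C@H]1CN(S(=O)(=O)c2ccc(N)nc2)CCN1c1ccc(C(O)(C(F)(F)F)C(F)(F)F)cn1` gives 42 mL.min-1.g-1
compound 2 `CC#C[C@H]1CN(S(=O)(=O)c2ccc(N)nc2)CCN1c1ccc(S(=O)(=O)NCC2CC2)cc1` gives 213 mL.min-1.g-1
compound 3 `CC#C[C@H]1CN(S(=O)(=O)c2ccc(N)nc2)CCN1c1ncc(C(C)(O)C(F)(F)F)s1` gives 87 mL.min-1.g-1

All three numbers come from an ADME assay (liver) for metabolic stability, with Liver microsome (Rattus norvegicus) as the target, using microsomes and NADPH, with a stated time of 30 min; on this read-out lower numbers stand for slow clearance and higher numbers for fast clearance. Among them compound 2 stands highest. Its nearest neighbour is compound 3, whose number is lower by a gap beyond the usual scatter of this assay, and the furthest is compound 1, lower still by a wider gap that also lies beyond the scatter. Going by the values given here, the three compounds share one core and differ only in the group carried on the aromatic ring at the right-hand end of that core, so the spread of the three values points to that group as the part that matters here, though with only three compounds nothing firmer can be said.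

Compound 4 `CC#C[C@H]1CN(S(=O)(=O)c2ccc(N)nc2)CCN1c1ccc(C(C)=O)cc1` has not been measured yet. It differs from compound 2 in one place: acetyl in place of (cyclopropylmethyl)sulfamoyl on an aromatic carbon. Among the compounds with values here, the group that enters is much smaller than the one that leaves, and no pair of measured compounds shows this exact change, so the size of the step is uncertain. Because compound 2 already gives 213 mL.min-1.g-1 while both other measured compounds lie well lower, a step downward of moderate size is expected, a 1.9-fold lower number from compound 2 to compound 4 (0.29 log units; within the scatter). Compound 4 is therefore estimated at 110 mL.min-1.g-1, with a range from 50 mL.min-1.g-1 to 240 mL.min-1.g-1.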

Compound 4, intrinsic clearance in microsomes: 249 mL.min-1.g-1
Compound 4: middle estimate off by 2.3-fold (0.35 log units), on the low side; measured number outside the range, above it.
By their numbers in this assay, from the lowest: compound 1; then compound 3; then compounds 2 and 4 (each within the scatter of the next).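

In this assay, acetyl in place of (cyclopropylmethyl)sulfamoyl on this aromatic carbon, para to a large group, gives a 1.2-fold higher number from compound 2 to compound 4 (0.07 log units; within the scatter), so compound 2 and compound 4 cannot be told apart. Going by these compounds alone, this is the first direct view of a change at this position: going from 8 heavy atoms to 3, and losing the three-membered ring and the hydrogen-bond donor, leaves the number within the usual scatter for this one pair. No measurement shown here explains why these two quite different groups give such similar numbers.

A carboxylic acid, a simple amine or a longer chain on the same aromatic carbon could show whether this position tolerates other groups as well, or whether this pair is a special case. Compound 1 and compound 3 differ from compound 4 in both the aromatic ring and the group it carries, so the compounds shown cannot separate the contribution of the ring from that of the group to their lower numbers.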